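The compounds below may be only part of what the source reports. "The series", "measured", "known", "first", "only" and "open" are said of these compounds alone.

Compound 2 `CCOC(=O)Cn1c(=O)n(C2OC(CO)[C@@H](O)[C@H]2O)c2nc(N)nc(O)c21` gives 48 uM in a functional assay (B cells) with Mus musculus as the target (on this read-out lower numbers stand for an effect already at smaller amounts and higher numbers for an effect only at larger amounts of compound), the highest of the three numbers recorded, though its nearest neighbour, compound 1 `[N-]=[N+]=NCC(O)Cn1c(=O)n(C2OC(CO)[C@@H](O)[C@H]2O)c2nc(N)nc(O)c21`, gives 39 uM in this assay, a gap that lies within the scatter. Going by the values given here, compound 3 `C=CCn1c(=O)n(Cc2ccccc2)c2nc(N)nc(O)c21` gives 5 uM in this assay, the only one of the three numbers that sits clearly apart from compound 2.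

The next step leads to compound 4 `NC(=O)Cn1c(=O)n(C2OC(CO)[C@@H](O)[C@H]2O)c2nc(N)nc(O)c21`. The change is amino in place of ethoxy on a carbonyl carbon, and it leaves the rest of the shared core untouched. Among the compounds with values here, only one measured step bears on it: the move along the same chain, a 1.2-fold higher number from compound 1 to compound 2 (0.09 log units; within the scatter), which exchanged one substituent for another on the saturated chain carbon bound to the aromatic nitrogen and left the number where it was. Compound 3 differs from compound 2 in more than one place, so its lower number cannot be tied to the chain alone. On that basis the change at the carbonyl carbon is expected to matter little, and the step of a 1.1-fold lower number from compound 2 to compound 4 (0.03 log units; within the scatter) is estimated to fall within the scatter. Compound 4 is therefore expected to give about 45 uM in this assay, within a range of 20 uM to 100 uM.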

Compound 4, concentration for half-maximal effect: 190 uM
Estimate against measurement, compound 4: 4.2-fold (0.63 log units) below; measured number above the stated range.
By their numbers in this assay, from the lowest: compound 3; then compounds 1 and 2 (each within the scatter of the next); then compound 4.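

In this assay, going by these compounds alone, the carbonyl carbon of this chain turns out not to be indifferent to what it carries: amino in place of ethoxy gives a 4.0-fold higher number from compound 2 to compound 4 (0.60 log units; beyond the scatter), the first step to lie beyond the scatter. Measured against the azido-bearing chain, carbamoyl in place of 2-azido-1-hydroxyethyl gives a 4.9-fold higher number from compound 1 to compound 4 (0.69 log units; beyond the scatter), so the group on the saturated chain carbon can shift the number, although ethoxycarbonyl in place of the same group gave only a 1.2-fold higher number from compound 1 to compound 2 (0.09 log units; within the scatter), within the scatter. Nothing available here accounts for the shift that comes with the amino group.

The compounds shown leave open whether the number follows the departure of ethoxy or the arrival of amino, a question that a methoxy, methylamino or dimethylamino group or a free carboxylic acid on the same carbonyl carbon would help to separate. Within the data shown here, they also leave open whether carbamoylmethyl in place of (ethoxycarbonyl)methyl would move the number in the same way on a core carrying a different group from the one shared by compound 2 and compound 4.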